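The source may hold more compounds than are shown below. What is called first, only, known or untested is meant among the compounds shown, and "the series" means these compounds.

Measured in a functional assay on thoracic aorta (Rattus norvegicus, strain Wistar), with a stated time of 15 min; a lower number here means that less compound is needed, a higher number that more compound is needed for the effect:
- compound 1 `COc1ccc(F)cc1C(C)NC(=O)N(C)S(=O)(=O)c1ccc(Cl)cc1`: 12600 nM
- compound 2 `COc1ccc(Br)cc1C(C)NC(=O)N(C)S(=O)(=O)c1ccccc1`: 16800 nM

With only these two numbers, compound 2 stands within the usual scatter of compound 1, so repeated measurements could not reliably tell the two apart. Both need a concentration in the same broad range to give the half-maximal effect.

The next compound is compound 3 `COc1ccc(Br)cc1C(C)NC(=O)N(C)S(=O)(=O)c1ccc(Cl)cc1`, which turns the phenyl of compound 2 into a 4-chlorophenyl, with chloro in place of hydrogen on an aromatic carbon, para to a large group: chloro in place of hydrogen on an aromatic carbon.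

Within the data shown here, no two measured compounds differ in one place only, so the size of this change has not been seen directly. Among the measured compounds shown here, the only guide is compound 1, which also carries a 4-chlorophenyl and gives 12600 nM. That value gives no sign of a large shift, so no step beyond the scatter is expected in this assay.

The expected change is small, an estimated 1.3-fold lower number from compound 2 to compound 3 (0.11 log units; within the scatter).

For compound 3 the estimated value is 13000 nM, with an expected range of 5500 nM to 30000 nM.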

Compound 3, half-maximal effective concentration: 19100 nM
Estimate against measurement, compound 3: 1.5-fold (0.17 log units) below; low and high end bracket the measured number.
By their numbers in this assay, from the lowest: compounds 1, 2 and 3 (each within the scatter of the next).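

In this assay, among these compounds, chloro in place of hydrogen on an aromatic carbon, para to a large group, gives a 1.1-fold higher number from compound 2 to compound 3 (0.06 log units; within the scatter) and is the first direct reading of this swap; the two compounds cannot be told apart at this position. The halogen on the other aromatic ring gives the same kind of result, as bromo in place of fluoro on an aromatic carbon gives a 1.5-fold higher number from compound 1 to compound 3 (0.18 log units; within the scatter) and also leaves the two compounds indistinguishable. Nothing available here offers an explanation for either result.

On these data alone, with only these single swaps, it remains open whether any group at either position can move the number beyond the scatter, for example an amine or a carboxylic acid in place of the chloro, or a longer chain in place of the methoxy group on the other ring. As far as these compounds go, it is also open whether the flat result holds for other halogen combinations, such as fluoro on the ring that carries the methoxy group with an unsubstituted phenyl on the other side, since a single example of each swap cannot show how general it is.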